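Methyl to Cyclobutyl on an Oxygen

The source may report more compounds than this note shows. Statements on the series, on what has been measured and on what is new or still open speak of the compounds shown alone.

Compound 1 `COc1cc(-c2nnc3c(OC)cc(-c4ccc5[nH]ccc5c4)cn23)cc(OC)c1OC` is the starting point, and in a functional assay on HCT-116 cells (Homo sapiens) for antiproliferative activity, read by MTT assay, with a stated time of 48 h (on this read-out higher numbers stand for weaker inhibition and lower numbers for stronger inhibition), compound 1 gives 108 nM. Compound 2 `COc1cc(-c2nnc3c(OC)cc(-c4ccc5[nH]cc(C=O)c5c4)cn23)cc(OC)c1OC` gives > 10000 nM, which is a limit of the assay and not a number. Compound 3 `COc1cc(-c2nnc3c(OC)cc(-c4ccc5c(ccn5C)c4)cn23)cc(OC)c1OC` gives 33 nM, the lowest number of the three compounds.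

Compound 4 `COc1cc(-c2nnc3c(OC4CCC4)cc(-c4ccc5c(ccn5C)c4)cn23)cc(OC)c1OC` keeps compound 3 intact except for one exchange, methoxy to cyclobutyloxy: cyclobutyl in place of methyl on an oxygen on an aromatic ring. Going by the values given here, no measured step touches this oxygen, so the available steps offer only loose guidance. Placing formyl on an aromatic carbon gave an at least 92-fold higher number from compound 1 to compound 2 (1.96 log units; beyond the scatter), which shows that a single change can cost a great deal of activity in this series. Placing methyl on an aromatic nitrogen gave only a 3.3-fold lower number from compound 1 to compound 3 (0.51 log units; beyond the scatter). A moderate rise in this assay therefore seems the most reasonable expectation, though with wide uncertainty. The expected change is a 3.6-fold higher number from compound 3 to compound 4 (0.56 log units; beyond the scatter). For compound 4 the estimated value is 120 nM, with an expected range from 25 nM to 1000 nM.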

Compound 4, half-maximal inhibitory concentration: 750 nM
The estimate for compound 4 lay 6.3-fold (0.80 log units) below the measured number, and the stated range covers the measured number.
By their numbers in this assay, from the lowest: compound 3; then compound 1; then compound 4. At a limit, above all of these: compound 2.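

This oxygen had not been touched by any earlier step, and it proves sensitive: exchanging methoxy for cyclobutyloxy gives a 23-fold higher number from compound 3 to compound 4 (1.36 log units; beyond the scatter) in this assay. That step is far larger than the gain from methyl on the aromatic nitrogen, a 3.3-fold lower number from compound 1 to compound 3 (0.51 log units; beyond the scatter), so at this position on the shared core, cyclobutyl in place of methyl is a costly exchange, even though compound 4 still gives a measurable number. Compound 2 alone remains at a limit of the assay, not a number: the limit of > 10000 nM in this assay, at which 1 of the 4 values shown sits.

Only methyl and cyclobutyl are shown on this oxygen, so it stays open whether the loss follows the ring itself or simply the larger number of carbons. An ethyl group, an open butyl chain or a chain ending in an amine on the same oxygen would help separate these possibilities.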